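A few compounds are considered here, and "the series" means these few. Any claim that something is new, unique, unknown or untested is made for them only; others in the source may bear on it.

Compounds measured in an ADME assay on HepG2 cells (Homo sapiens) for cytotoxicity, read by luminescence, CellTiter-Glo and ATP content, with a stated time of 72 h; a lower number here means that less compound is needed, a higher number that more compound is needed for the effect:
compound 1 `COc1ccc(F)cc1CNCCCNc1ccnc2cc(C3CCCCC3)ccc12` gives 2290 nM;
compound 2 `COc1cccc(Oc2ccc3c(NCCCNCc4cc(F)ccc4OC)ccnc3c2)c1` gives 7100 nM;
compound 3 `COc1ccc(-c2ccc3c(NCCCNCc4cc(F)ccc4OC)ccnc3c2)cc1` gives 5960 nM.

Compound 3 stands close to compound 2, the step of a 1.2-fold lower number from compound 2 to compound 3 (0.08 log units; within the scatter) lying within the scatter, while compound 1 is separated from it by a 2.6-fold higher number from compound 1 to compound 3 (0.42 log units; beyond the scatter). Compound 4 `COc1ccc(F)cc1CNCCCNc1ccnc2cc(Oc3ccc(Cl)cc3)ccc12` is the next member of the series; its change from compound 3 is 4-chlorophenoxy in place of 4-methoxyphenyl on an aromatic carbon. The most relevant comparison is a 1.2-fold lower number from compound 2 to compound 3 (0.08 log units; within the scatter), where one aryl substituent gave way to an aryloxy substituent without a step beyond the scatter, and a 3.1-fold higher number from compound 1 to compound 2 (0.49 log units; beyond the scatter) and a 2.6-fold higher number from compound 1 to compound 3 (0.42 log units; beyond the scatter) show that both aryl and aryloxy groups sit in the same range. A step of a 1.1-fold higher number from compound 3 to compound 4 (0.04 log units; within the scatter) is therefore expected, staying within the scatter. Compound 4 is estimated at 6500 nM, within 3000 nM to 14000 nM.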

Compound 4, half-maximal effective concentration: 4500 nM
Compound 4: middle estimate off by 1.4-fold (0.16 log units), on the high side; the range from low to high includes it.
By their numbers in this assay, from the lowest: compounds 1, 4, 3 and 2 (each within the scatter of the next, the first and the last beyond it).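

In this assay, 4-chlorophenoxy in place of 4-methoxyphenyl on this aromatic carbon stays within the scatter (a 1.3-fold lower number from compound 3 to compound 4 (0.12 log units; within the scatter)), as does the exchange of the aryl group on the oxygen (a 1.6-fold lower number from compound 2 to compound 4 (0.20 log units; within the scatter)). Unlike compound 2 and compound 3, compound 4 is not separated from the cyclohexyl group of compound 1 (a 2.0-fold higher number from compound 1 to compound 4 (0.29 log units; within the scatter)), so at this position an aromatic substituent need not lie beyond the scatter from cyclohexyl. No evidence bearing on these readings is available. The compounds shown leave open how an amine or a carboxylic acid on this carbon would read.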